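Shortening the imidazole substituent in a piperazine series

A few compounds are considered here, and "the series" means these few. Any claim that something is new, unique, unknown or untested is made for them only; others in the source may bear on it.

Compound 1 `CCc1cc(CN2CCN(c3cccc4[nH]c(-c5ccc(C(C)(C)C)cc5)nc34)CC2)n(C)n1`: 250 nM in an assay on isolated protein for displacement of a labelled ligand from Gonadotropin-releasing hormone receptor (Rattus norvegicus); on this read-out lower numbers stand for stronger inhibition and higher numbers for weaker inhibition
Compound 2 `CCCCn1cnc(CN2CCN(c3cccc4[nH]c(-c5ccc(C(C)(C)C)cc5)nc34)CC2)c1C`: 49 nM in this assay

In this assay compound 2 holds the lowest of the two numbers, the gap being a 5.1-fold lower number from compound 1 to compound 2 (0.71 log units; beyond the scatter). Compound 3 `Cc1nc(CN2CCN(c3cccc4[nH]c(-c5ccc(C(C)(C)C)cc5)nc34)CC2)cn1C` differs from it by 1,2-dimethyl-1H-imidazol-4-yl in place of 1-butyl-5-methyl-1H-imidazol-4-yl on a saturated chain carbon bound to an amine nitrogen in a ring. Among the measured compounds shown here, the only measured step, a 5.1-fold lower number from compound 1 to compound 2 (0.71 log units; beyond the scatter), swapped one heteroaryl for another and bears only loosely on this change, which keeps the imidazole and alters its substituents. A modest step upward in this assay is expected, since compound 1 with a smaller heteroaryl gave 250 nM. Compound 3 is therefore estimated at 120 nM, ranging from 40 nM to 400 nM. This estimate means an expected 2.4-fold higher number from compound 2 to compound 3 (0.39 log units; beyond the scatter).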

Compound 3, half-maximal inhibitory concentration in the Gonadotropin-releasing hormone receptor assay: 34 nM
For compound 3 the middle estimate is 3.5-fold (0.55 log units) above the measured one; measured number below the stated range.
By their numbers in the Gonadotropin-releasing hormone receptor assay, from the lowest: compounds 3 and 2 (each within the scatter of the next); then compound 1.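

In the Gonadotropin-releasing hormone receptor assay the exchange of 1-butyl-5-methyl-1H-imidazol-4-yl for 1,2-dimethyl-1H-imidazol-4-yl leaves no readable difference, at a 1.4-fold lower number from compound 2 to compound 3 (0.16 log units; within the scatter), so the butyl chain is not required at this position. The 3-ethyl-1-methyl-1H-pyrazol-5-yl group remains clearly apart from the smaller imidazole, with a 7.4-fold lower number from compound 1 to compound 3 (0.87 log units; beyond the scatter). The same exchange does separate the pair in a physicochemical assay for solubility, at pH 7.4 (on this read-out lower numbers stand for lower solubility and higher numbers for higher solubility), where compound 2 gives 3 ug/mL and compound 3 gives 51 ug/mL: the measured solubility of compound 2, 3 ug/mL, and of compound 3, 51 ug/mL, a 17-fold higher number (1.23 log units; beyond the scatter)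

The compounds shown do not tell the butyl chain's share of this result from that of the methyl groups. From the compounds shown here alone, whether an imidazole carrying an amine or a carboxylic acid on its chain would hold both read-outs also stays open.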